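This account rests on a few compounds, and the source may have more. Where it says the series, first, only, none or still open, it means among the compounds named here.

Measured so far in a functional assay on PLC5 cells (Homo sapiens) for cytotoxicity, read by MTT assay; on this read-out higher numbers stand for weaker inhibition and lower numbers for stronger inhibition:
- compound 1 `COC1=CC(c2cc3ccccc3n2C(=O)OC(C)(C)C)=N/C1=C\c1ccc[nH]1`: > 40000 nM
- compound 2 `COC1=CC(C2SCCCS2)=N/C1=C\c1[nH]c(C)cc1C`: > 40000 nM
- compound 3 `COC1=CC(c2cccs2)=N/C1=C\c1cccs1`: 25900 nM

The value given for compound 2, > 40000 nM, is a limit of the assay and not a number. The value for compound 1 is likewise a limit. Compound 3 is the only one of the three with a number, 25900 nM, and it sits in the weak range. The position of compound 2 is therefore described only by the limit of > 40000 nM in this assay, at which 2 of the 3 values shown sit. Within the data shown here, no pair of measured compounds differs in a single place, so no measured step is available for sizing.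

Compound 4 `COC1=CC(c2cccs2)=N/C1=C\c1[nH]c(C)cc1C` has not yet been measured. It differs from compound 2 by a group of 5 heavy atoms (4 carbon, 1 sulfur; one five-membered aromatic ring with 1 hetero atom) in place of a group of 6 heavy atoms (4 carbon, 2 sulfur; one six-membered non-aromatic ring with 2 hetero atoms), on a carbon with a double bond to nitrogen. Among the measured compounds shown here, compound 3, which also carries thiophen-2-yl on the shared core, gives a weak number rather than a limit, which is the only guide. With compound 2 at a limit, the step cannot be quantified; the expected shift an at least 1.3-fold lower number from compound 2 to compound 4 (0.12 log units; that floor lies within the scatter) is stated as a guess only, towards a measurable but still weak value. For compound 4 the estimate is 30000 nM, expected between 12000 nM and 40000 nM, with a real chance that the read-out again stops at the limit.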

Compound 4, half-maximal inhibitory concentration: > 40000 nM
Compound 4: a limit, no number; the forecaster's own chance of this, stated with the estimate: 45%; middle value at least 1.3-fold (0.12 log units) away from the limit.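

Compound 2 and compound 4 both give a limit and not a number, so no step can be read between them: the limit of > 40000 nM in this assay, at which 3 of the 4 values shown sit.

The compounds shown leave open whether thiophen-2-yl in place of the six-membered non-aromatic ring changes the read-out at all on the shared core.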